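Swapping Cyclopropyl for Phenyl on a Fused Core

A few compounds are considered here, and "the series" means these few. Any claim that something is new, unique, unknown or untested is made for them only; others in the source may bear on it.

Three compounds sharing a fused core were tested in a functional assay on MCF7 cells (Homo sapiens) for inhibition, read by fluorescence, with a stated time of 72 h; on this read-out higher numbers stand for weaker inhibition of growth and lower numbers for stronger inhibition of growth. Compound 1 `CC(C)c1nccc2nn(-c3ccccc3)cc12` gives 98800 nM, compound 2 `Cc1nc(C2CC2)cc2nn(-c3ccccc3)cc12` gives 63500 nM, and compound 3 `CCCCc1cc2nn(-c3ccccc3)cc2cn1` gives 13300 nM. On these numbers compound 2 stands second highest of the three: the number for compound 1 lies within the usual scatter of it, while compound 3 shows a lower number that lies beyond the scatter. Compound 4 `Cc1nc(-c2ccccc2)cc2nn(-c3ccccc3)cc12` differs from compound 2 in one place: phenyl in place of cyclopropyl on an aromatic carbon. Among the compounds with values here, no measured pair shows this exact change, so the expectation rests on thin footing. A modest step toward a lower number is expected, a 2.1-fold lower number from compound 2 to compound 4 (0.33 log units; beyond the scatter), possibly still within the scatter. Compound 4 is expected to give 30000 nM, within 8000 nM to 120000 nM.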

Compound 4, concentration for 50% growth inhibition: 11000 nM
For compound 4 the middle estimate is 2.7-fold (0.44 log units) above the measured one; low and high end bracket the measured number.
By their numbers in this assay, from the lowest: compounds 4 and 3 (each within the scatter of the next); then compounds 2 and 1 (each within the scatter of the next).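

In this assay, phenyl in place of cyclopropyl on an aromatic carbon next to the ring nitrogen gives a 5.8-fold lower number from compound 2 to compound 4 (0.76 log units; beyond the scatter) and is the first change in one place among these compounds. It shows that this position responds to the group it carries, with the aromatic phenyl going with stronger inhibition of growth than cyclopropyl in this single pair. Nothing shown gives a reason for the step.

As far as these compounds go, whether an amine, a carboxylic acid or a longer chain at this position would lower the number further remains open. So does whether phenyl would have the same effect without the neighbouring methyl group on the shared core.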